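This account rests on a few compounds, and the source may have more. Where it says the series, first, only, none or still open, it means among the compounds named here.

Compound 1 has the structure `COc1nc(C(C)(C)C)ccc1[C@@H](c1ccccc1)[C@@](O)(CCN(C)C)c1cccc2ccccc12`. In a toxicity assay on HeLa cells (Homo sapiens) for cytotoxicity (a higher number here means that more compound is tolerated, a lower number that less compound is tolerated), compound 1 gives > 64 ug/mL, which is a limit of the assay rather than a number.
Compound 2 has the structure `COc1nc(-c2ccc(Br)cc2)ccc1[C@@H](c1ccccc1)[C@@](O)(CCN(C)C)c1cccc2ccccc12`. In this assay compound 2 gives > 64 ug/mL, again a limit of the assay and not a number.
Compound 3 has the structure `COc1ncc(-c2ccccc2)cc1[C@@H](c1ccccc1)[C@@](O)(CCN(C)C)c1cc(F)ccc1F`. In this assay compound 3 gives "nd" (no result reported), so no result was reported for it.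

Compound 2 therefore stands at a limit of this assay, not at a measured number, and it shares that position with one other compound: the limit of > 64 ug/mL in this assay, at which 2 of the 3 values shown sit. Going by the values given here, the single comparison between measured compounds that differ in one place, a step that the two limits leave unreadable from compound 1 to compound 2, cannot be read for size, since both of its ends are limits. So no measured step gives a usable size for what follows.

Compound 4, with the structure `COc1nc(-c2ccccc2Cl)ccc1[C@@H](c1ccccc1)[C@@](O)(CCN(C)C)c1cccc2ccccc12`, has not yet been measured in this assay. It differs from compound 2 in one place: 2-chlorophenyl in place of 4-bromophenyl on an aromatic carbon. Among the compounds with values here, with both measured values sitting at the limit and the only step unreadable, the step of a number no higher from compound 2 to compound 4 (the limit leaves the size open) is expected to show no change beyond the scatter. Compound 4 is estimated to give 64 ug/mL, with a range from 32 ug/mL to 128 ug/mL, and a limit rather than a number is the more likely report.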

Compound 4, half-maximal cytotoxic concentration: > 64 ug/mL
Compound 4 gave a limit, no number; the forecaster's own chance of this, stated with the estimate: 70%; the middle value sits exactly at the limit.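

In this assay compound 4 gives > 64 ug/mL (a limit, not a number). The steps joining compound 4 to compound 1 and compound 2 therefore cannot be read for size, with both ends of each at a limit: the limit of > 64 ug/mL in this assay, at which 3 of the 4 values shown sit.
Left open is how much of any of these compounds is tolerated in this assay and whether the exchanged groups make any difference there.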